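The compounds below may be only part of what the source reports. "The series", "measured", "known", "first", "only" and "open" are said of these compounds alone.

Compound 1 `CC(C)=CCOc1ccc2c(c1)OC(c1ccccc1)CC2=O` carries the shared core, and in a functional assay (a higher number here means a weaker inhibitor, a lower number a stronger inhibitor), compound 1 gives 6070 nM. Compound 2 `CC(C)=CCOc1ccc2c(c1)OC(c1cccc(Br)c1)CC2=O` gives 5280 nM and compound 3 `CC(C)=CCOc1ccc2c(c1)OC(c1ccc(Br)cc1)CC2=O` gives 8120 nM in this assay, so compound 1 stands second highest of the three numbers, though a 1.1-fold lower number from compound 1 to compound 2 (0.06 log units; within the scatter) and a 1.3-fold higher number from compound 1 to compound 3 (0.13 log units; within the scatter) are both within the scatter. Compound 4 `CC(C)=CCOc1ccc2c(c1)OC(c1ccc(C)cc1)CC2=O` differs from compound 1 by methyl in place of hydrogen on an aromatic carbon. Both measured steps from compound 1, each adding a single bromo to the same ring, stayed within the scatter, and a 1.5-fold higher number from compound 2 to compound 3 (0.19 log units; within the scatter) did likewise. No step beyond the scatter is therefore expected in this assay in either direction. Compound 4 is estimated at 6500 nM, in the range 3000 nM to 14000 nM, the expected step being a 1.1-fold higher number from compound 1 to compound 4 (0.03 log units; within the scatter).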

Compound 4, half-maximal inhibitory concentration: 4440 nM
Estimate against measurement, compound 4: 1.5-fold (0.17 log units) above, within the range that was stated.
By their numbers in this assay, from the lowest: compounds 4, 2, 1 and 3 (each within the scatter of the next).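

In this assay, the step from phenyl to 4-methylphenyl gives a 1.4-fold lower number from compound 1 to compound 4 (0.14 log units; within the scatter), so methyl at this aromatic carbon, para to a large group, joins bromo in producing no step beyond the scatter. Exchanging the two groups at this carbon gives a 1.8-fold lower number from compound 3 to compound 4 (0.26 log units; within the scatter), and 4-methylphenyl in place of 3-bromophenyl gives a 1.2-fold lower number from compound 2 to compound 4 (0.08 log units; within the scatter), so these substituted rings also remain within the scatter of one another. From the compounds shown here alone, whether an amine or a carboxylic acid on this ring would produce a step beyond the scatter remains open. No measurement available here bears on why these steps are small.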